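Swapping One Ring Group on the Least Bound Compound

This account rests on a few compounds, and the source may have more. Where it says the series, first, only, none or still open, it means among the compounds named here.

In an ADME assay on a cell-free system (plasma, Mus musculus) for protein binding, read by LC-MS, with a stated time of 4 h, tested at 10 uM, compound 1 (`O=C1COCCN1c1ccc(C2CC(c3ccc([N+](=O)[O-])o3)=NO2)cn1`) shows 58.9%, the lowest figure and so the largest free share among the three measured compounds. Compound 2 (`O=C1COCCN1c1ccc(C2CC(c3ccc([N+](=O)[O-])o3)=NO2)cc1F`) shows 79.7% and compound 3 (`CN1CCN(c2ccc(C3CC(c4ccc([N+](=O)[O-])o4)=NO3)cc2F)C(=O)C1`) shows 82.8%. Compound 4 (`CN1CCN(c2ccc(C3CC(c4ccc([N+](=O)[O-])o4)=NO3)cn2)C(=O)C1`) keeps the core of compound 1 and changes one group: 4-methyl-2-oxopiperazin-1-yl in place of 3-oxomorpholin-4-yl on an aromatic carbon is the whole difference. For the measured compounds named here, the same swap was measured once on a different core, giving a 1.2-fold lower unbound fraction from compound 2 to compound 3 (0.07 log units; within the scatter) as the only guide. On that single step, this assay should show no change beyond the scatter, at most slightly less free compound. The expected step is a 1.1-fold lower unbound fraction from compound 1 to compound 4 (0.06 log units; within the scatter) in size. Compound 4 is estimated at 64% (range 46% to 78%).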

Compound 4, plasma protein binding: 59.8%
Compound 4: middle estimate off by 1.1-fold (0.05 log units) (unbound fraction), on the low side, within the range that was stated.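

Next to the ring nitrogen on the core of compound 1, 4-methyl-2-oxopiperazin-1-yl in place of 3-oxomorpholin-4-yl gives a 1.0-fold lower unbound fraction from compound 1 to compound 4 (0.01 log units; within the scatter) and so leaves binding to plasma protein without a readable change. In this assay the swap has now been read on two cores instead of one, and the two readings agree: the same change on two cores in this assay, a 1.2-fold lower unbound fraction (0.07 log units; within the scatter) from compound 2 to compound 3 and a 1.0-fold lower unbound fraction (0.01 log units; within the scatter) from compound 1 to compound 4, 1.2-fold (0.06 log units) apart, within the scatter of two such steps.

Both groups compared are six-membered non-aromatic rings with no net charge. From the compounds shown here alone, whether an open-chain amine or a carboxylic acid in this place would move the binding stays open.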